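A few compounds are considered here, and "the series" means these few. Any claim that something is new, unique, unknown or untested is made for them only; others in the source may bear on it.

In a functional assay on MCF7 cells (Homo sapiens) for inhibition, read by sulforhodamine B assay, with a stated time of 48 h, tested at 50 uM (on this read-out lower numbers stand for less inhibition of growth and higher numbers for more inhibition of growth at the one concentration tested), compound 1 `COc1ccc([C@@H]2C/C(=N/OCc3cn(-c4ccc(C#N)cc4)nn3)c3cc(CC=C(C)C)c(OC)cc3O2)cc1` gives 40% and compound 2 `COc1ccc([C@@H]2C/C(=N/OCc3cn(-c4cc(OC)c(OC)c(OC)c4)nn3)c3cc(CC=C(C)C)c(OC)cc3O2)cc1` gives 45%, so these two numbers lie within the scatter of each other. Compound 3 `COc1ccc([C@@H]2C/C(=N/OCc3cn(-c4ccc(NC(=O)c5ccccc5)cc4)nn3)c3cc(CC=C(C)C)c(OC)cc3O2)cc1` keeps the core of compound 1 and alters one group: benzamido in place of cyano on an aromatic carbon, para to a large group (benzamido in place of cyano on an aromatic carbon). For the measured compounds named here, only one measured step bears on this change, a number 5 percentage points higher from compound 1 to compound 2 (within the scatter), and it swaps the whole aromatic group on the same nitrogen. No shift beyond the scatter is therefore expected, and the estimated step is a number 3 percentage points higher from compound 1 to compound 3 (within the scatter). Compound 3 is expected to give 43%, with an estimated range of 25% to 60%.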

Compound 3, percent growth inhibition at one concentration: 4%
Beside the measured number, compound 3's estimate is 39 percentage points above it, and the stated range ends above it.
By their numbers in this assay, from the lowest: compound 3; then compounds 1 and 2 (each within the scatter of the next).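

In this assay, the aromatic carbon para to a large group proves sensitive to what it carries: benzamido in place of cyano gives a number 36 percentage points lower from compound 1 to compound 3 (beyond the scatter). For the compounds shown here, the earlier step swapped the whole aromatic group and stayed within the scatter, so this is the first sign that a change here can cost most of the growth inhibition. No measurement shown accounts for the drop. Benzamido adds both a carbon ring and an amide hydrogen, and the compounds shown do not separate these two features. Acetamido or a plain amine at this position could tell them apart.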